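Chloro to Trifluoromethoxy on the Aryl Ring of Compound 1

A few compounds are considered here, and "the series" means these few. Any claim that something is new, unique, unknown or untested is made for them only; others in the source may bear on it.

Compound 1 `O=C(/C(=C\c1ccc(Cl)cc1)Sc1ccc(Br)cc1)c1ccc(Br)cc1`: 1000 nM
Compound 2 `COc1cc(/C=C(/Sc2ccc(Br)cc2)C(=O)c2ccc(Br)cc2)ccc1O`: 1000 nM

In a functional assay on DU-145 cells (Homo sapiens) for inhibition, read by trypan blue exclusion, with a stated time of 96 h (a higher number here means a weaker inhibitor of growth, a lower number a stronger inhibitor of growth), compound 1 gives 1000 nM and stands level with compound 2, the step of no change at the digits printed from compound 1 to compound 2 (within the scatter) lying within the scatter. Compound 3 `O=C(/C(=C\c1ccc(OC(F)(F)F)cc1)Sc1ccc(Br)cc1)c1ccc(Br)cc1` is not yet measured; it differs from compound 1 by trifluoromethoxy in place of chloro on an aromatic carbon. Among the measured compounds shown here, the only measured step that bears on it is the one from compound 1 to compound 2, which altered the same ring and produced no change beyond the scatter. A step of similar size, no change at the digits printed from compound 1 to compound 3 (within the scatter), is therefore expected, with no clear direction. Compound 3 is estimated at 1000 nM, between 400 nM and 2500 nM.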

Compound 3, concentration for 50% growth inhibition: 10000 nM
For compound 3 the middle estimate is 10-fold (1.00 log units) below the measured one; the whole stated range lies below it.
By their numbers in this assay, from the lowest: compounds 1 and 2 (each within the scatter of the next); then compound 3.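

In this assay, this position proves sensitive to the group it carries: trifluoromethoxy in place of chloro gives a 10-fold higher number from compound 1 to compound 3 (1.00 log units; beyond the scatter) while the earlier change on the same ring gave no change at the digits printed from compound 1 to compound 2 (within the scatter) and left the number in place. Among these three compounds, then, chloro can be replaced on this ring without a shift, but not by every group. Nothing measured here accounts for why the two replacements differ. On these data alone, whether fluoro, methoxy alone or an amine on this carbon would stay level with compound 1 or move towards compound 3 remains open.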